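Swapping a methyl position on a dienone-derived anilinomethyl series

This account rests on a few compounds, and the source may have more. Where it says the series, first, only, none or still open, it means among the compounds named here.

Compound 1 `Cc1ccc(N(C)CC2CCC/C(=C\c3ccccc3)C2=O)cc1` and compound 2 `Cc1cccc(N(C)CC2CCC/C(=C\c3ccccc3)C2=O)c1` share one core and differ only in where a methyl sits on the aromatic ring attached to the amine nitrogen. In a functional assay on the whole organism (Ear, strain Kunming) for inhibition, with Mus musculus as the target, with stated times of 1 h and 30 min, at a dose of 200 mg/kg by the oral route (a lower number here means less inhibition, a higher number more inhibition at the dose given (going by the name of the read-out)), compound 1 gives 18.3%, while compound 2 gives 44.9%, so the change 3-methylphenyl in place of 4-methylphenyl on an amine nitrogen produced a number 26.6 percentage points higher from compound 1 to compound 2 (beyond the scatter). Compound 3 `Cc1ccc(N(C)CC2CCC/C(=C\c3ccccc3)C2(O)c2ccccc2)cc1` carries a different core, and the difference between the two cores is not broken down here; in this assay compound 3 gives 66.7%. Compound 4 `Cc1cccc(N(C)CC2CCC/C(=C\c3ccccc3)C2(O)c2ccccc2)c1` arises from compound 3 by the same change, (3-methylphenyl in place of 4-methylphenyl on an amine nitrogen), at the same place. Because the step of a number 26.6 percentage points higher from compound 1 to compound 2 (beyond the scatter) was modest but clear, compound 4 is expected to rise by a number 13.3 percentage points higher from compound 3 to compound 4 (beyond the scatter), somewhat less given how high compound 3 already stands. The estimated inhibition for compound 4 is 80%, expected between 62% and 95%.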

Compound 4, a percentage reported as inhibition, in the whole organism at one dose (the size of the read-out at that dose, not a potency): 23.1%
Compound 4: middle estimate off by 56.9 percentage points, on the high side, outside the stated range (below it).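

In this assay, the change from 4-methylphenyl to 3-methylphenyl on the amine nitrogen gives a number 43.6 percentage points lower from compound 3 to compound 4 (beyond the scatter), so the step seen on the first core does not carry over to the second in either direction or size: the same change on two cores in this assay, a number 26.6 percentage points higher (beyond the scatter) from compound 1 to compound 2 and a number 43.6 percentage points lower (beyond the scatter) from compound 3 to compound 4, 70.2 percentage points apart, beyond the scatter of two such steps The outcome of this swap therefore depends on the core it is made on, at least in these two pairs. This does not show why the cores behave differently, and two pairs give no rule for any further core.

Going by these compounds, it remains open how a plain phenyl or a chlorophenyl on the amine nitrogen would behave on each core. The compounds shown also do not separate the roles of the hydroxyl and the added phenyl in compound 3.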